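The compounds below may be only part of what the source reports. "The series", "measured", "known", "first", "only" and "open" are said of these compounds alone.

Measured compounds:
- compound 1, `CN(C)CCn1cnnc1-c1cc(Oc2ccc(NC(=O)Nc3ccc(F)c(F)c3)cc2F)ccn1`, 17.6%
- compound 2, `CCN(CC)CCn1cnnc1-c1cc(Oc2ccc(NC(=O)Nc3cccc(C(F)(F)F)c3)cc2F)ccn1`, 72.1%
- compound 3, `CCN(CC)CCn1cnnc1-c1cc(Oc2ccc(NC(=O)Nc3ccccc3C(F)(F)F)cc2F)ccn1`, "not determined" (no result reported)

In an assay on isolated protein for inhibition of proto-oncogene tyrosine-protein kinase receptor Ret (Homo sapiens), read by mobility shift assay, with a stated time of 1 h, tested at 10 uM (on this read-out lower numbers stand for less inhibition and higher numbers for more inhibition at the one concentration tested (going by the name of the read-out)), compound 1 gives 17.6%, and compound 2 gives 72.1%. In this assay compound 3 gives "not determined" (no result reported), so it cannot be placed among the measured values; it stands only as a structure.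

Compound 4, `CCN(CC)CCn1cnnc1-c1cc(Oc2ccc(NC(=O)Nc3ccc(F)c(F)c3)cc2F)ccn1`, differs from compound 3 in one place: 3,4-difluorophenyl in place of 2-(trifluoromethyl)phenyl on an amide-type nitrogen. Within the data shown here, since compound 3 has no value, no step from compound 3 to compound 4 can be computed, and no size or direction of change beyond the scatter can be stated for it.

What remains is the spread shown by compound 1 and compound 2 in this assay: one well under half inhibition, the other well over. For compound 4 the expected result in this assay is estimated at 35%, with a range from 10% to 65%.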

Compound 4, a percentage reported as inhibition, at one concentration (the size of the read-out at that concentration, not a potency): 7.1%
Estimate against measurement, compound 4: 27.9 percentage points above; the whole stated range lies above it.
By their numbers in this assay, from the lowest: compound 4; then compound 1; then compound 2.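

With the diethylamino chain held fixed, 3,4-difluorophenyl in place of 3-(trifluoromethyl)phenyl on the amide-type nitrogen gives a number 65 percentage points lower from compound 2 to compound 4 (beyond the scatter) in this assay and so isolates the aryl group as a strong influence on this read-out, which compound 1 and compound 2 could not do because they differ in more than one place. With 3,4-difluorophenyl held fixed, diethylamino in place of dimethylamino gives a number 10.5 percentage points lower from compound 1 to compound 4 (beyond the scatter) as a much smaller step, so in these compounds the aryl group matters more than the amine end. Nothing shown here explains either step.

As far as these compounds go, the step from compound 3 to compound 4 cannot be read, so the effect of 2-(trifluoromethyl)phenyl at this position stays unknown. Also open, from the compounds shown here alone, is how a phenyl ring carrying a nitrile in place of the trifluoromethyl would read.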